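This account rests on a few compounds, and the source may have more. Where it says the series, first, only, none or still open, it means among the compounds named here.

Working notes on the thiophene series in an ADME assay on BJ cells (Homo sapiens), read by MTT assay, with a stated time of 72 h; a higher number here means a weaker inhibitor, a lower number a stronger inhibitor.

Compound 1 `CN(C)c1ncnc2c1c(-c1ccsc1)cn2[C@@H]1O[C@H](CO)[C@@H](O)[C@H]1O` carries a thiophen-3-yl group. In this assay compound 1 gives only a limit of the assay, > 100000 nM. Compound 3 `COc1nc(N)nc2c1c(-c1cccs1)cn2[C@@H]1O[C@H](CO)[C@@H](O)[C@H]1O` carries a thiophen-2-yl group, and in this assay compound 3 gives 99900 nM. Compound 2 `Cc1nc(N)c2c(-c3cccs3)cn([C@@H]3O[C@H](CO)[C@@H](O)[C@H]3O)c2n1` likewise carries a thiophen-2-yl group. In this assay compound 2 also gives only a limit of the assay, > 100000 nM. Compound 2 therefore stands where most of the series stands, because of the limit of > 100000 nM in this assay, at which 2 of the 3 values shown sit.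

Compound 4 `Cc1nc(N)c2c(-c3ccsc3)cn([C@@H]3O[C@H](CO)[C@@H](O)[C@H]3O)c2n1` has not yet been measured in this assay. It differs from compound 2 in one place: thiophen-3-yl in place of thiophen-2-yl on an aromatic carbon. For the measured compounds named here, no step between two measured compounds that differ in only this way is available, so the change cannot be read off a measured pair. The step from compound 2 to compound 4, a number no higher from compound 2 to compound 4 (the limit leaves the size open), is expected to be none beyond the scatter, since the same thiophen-3-yl group appears in compound 1 and compound 1 sits at the limit as well. Compound 4 is therefore expected to give about 100000 nM, within a range of 50000 nM to 200000 nM, most likely reported only as a limit.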

Compound 4, half-maximal inhibitory concentration: > 100000 nM
Compound 4 ended at the assay's limit (the forecaster's own chance of this, stated with the estimate: 85%); the middle value lies on the limit itself.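

Compound 2 and compound 4 both give only a limit in this assay, so the step from thiophen-2-yl to thiophen-3-yl cannot be read: the limit of > 100000 nM in this assay, at which 3 of the 4 values shown sit.

The compounds shown leave open whether these two thiophene groups differ at all on this core in this assay.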